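The source may hold more compounds than are shown below. What is called first, only, known or untested is meant among the compounds shown, and "the series" means these compounds.

Compound 1 `Cc1cccc(-c2cn3ccnc3c(-c3ccc4ncn(Cc5ccccc5)c4c3)n2)c1`: 19.3%
Compound 2 `O=Cc1ccc(-c2cn3ccnc3c(-c3ccc4ncn(Cc5ccccc5)c4c3)n2)cc1`: 16.9%

Both compounds were tested in a functional assay on OVCAR-4 cells (Homo sapiens) for inhibition, read by sulforhodamine B assay, with a stated time of 48 h, tested at 10 uM; on this read-out higher numbers stand for more inhibition at the one concentration tested (going by the name of the read-out) and lower numbers for less inhibition. Compound 2 has the lower of the two numbers, but the step of a number 2.4 percentage points lower from compound 1 to compound 2 (within the scatter) is within the scatter, so the two compounds cannot be told apart on this read-out. Compound 3 `c1ccc(Cn2cnc3ccc(-c4nc(-c5cccc6ccccc56)cn5ccnc45)cc32)cc1` differs from compound 2 in one place: naphthalen-1-yl in place of 4-formylphenyl on an aromatic carbon. For the measured compounds named here, only one measured step bears on this change, the exchange of one group on an aromatic carbon that gave a number 2.4 percentage points lower from compound 1 to compound 2 (within the scatter); it shows that swapping the group at this carbon has so far not moved the number beyond the scatter. Going by the values given here, the larger entering group has no measured counterpart, so the expectation rests on that single step. The expected step is a number 5.1 percentage points higher from compound 2 to compound 3 (within the scatter), which is no change beyond the scatter. Compound 3 is therefore estimated at 22%, with a range from 5% to 42%.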

Compound 3, a percentage reported as inhibition, at one concentration (the size of the read-out at that concentration, not a potency): 7.88%
Compound 3: the middle estimate sits 14.1 percentage points above what was measured, and the stated range covers the measured number.
By their numbers in this assay, from the lowest: compounds 3, 2 and 1 (each within the scatter of the next, the first and the last beyond it).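

In this assay, for the compounds shown here, the change to naphthalen-1-yl yields a number 11.4 percentage points lower from compound 1 to compound 3 (beyond the scatter) as the first step to clear the usual scatter, which shows that the group on this aromatic carbon can move the number, if only modestly. The comparison with 4-formylphenyl gives a number 9 percentage points lower from compound 2 to compound 3 (within the scatter) and so stays within the scatter, which means compound 2 cannot be told apart from either neighbour and only compound 1 and compound 3 separate. No measurement on hand explains why the number moves this way.

As far as these compounds go, all three groups at this carbon are aromatic rings of carbon, so it remains open how an amine, a carboxylic acid or a saturated morpholine ring would read here. From the compounds shown here alone, each number also comes from a single concentration, so how these compounds compare in potency remains open too.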